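The source may report more compounds than this note shows. Statements on the series, on what has been measured and on what is new or still open speak of the compounds shown alone.

In a functional assay on CCRF-CEM cells (Homo sapiens) for inhibition, read by cell counting, with a stated time of 3 days (a higher number here means a weaker inhibitor, a lower number a stronger inhibitor), compound 2 `C=C(Br)C(=O)Nc1cccc(-c2cn3nc(Cc4ccccc4)sc3n2)c1` gives 4200 nM, the lowest of the two numbers recorded. Within the data shown here, compound 3 `Nc1cccc(-c2cn3nc(Cc4ccccc4)sc3n2)c1` gives 37000 nM, and the one measured step, an 8.8-fold higher number from compound 2 to compound 3 (0.94 log units; beyond the scatter), concerns the nitrogen substituent rather than the five-membered ring. Compound 1 `CCOc1ccc(-c2nn3cc(-c4cccc(N)c4)nc3s2)cc1` gives only a limit, > 250000 nM, that being (the limit of > 250000 nM in this assay, at which 1 of the 3 values shown sits). Compound 4 `C=C(Br)C(=O)Nc1cccc(-c2cn3nc(-c4ccc(C)cc4)sc3n2)c1` differs from compound 2 by 4-methylphenyl in place of benzyl on an aromatic carbon. Among the measured compounds shown here, no measured step bears on this change: the step from compound 2 to compound 3 alters another group, and compound 1 is a limit on a differently joined core. Compound 4 is therefore expected to show a step of a 1.1-fold higher number from compound 2 to compound 4 (0.03 log units; within the scatter) of no clear direction, within the scatter. Compound 4 is estimated at 4500 nM, between 1000 nM and 25000 nM.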

Compound 4, half-maximal inhibitory concentration: 1700 nM
Compound 4: middle estimate off by 2.6-fold (0.42 log units), on the high side; the measured number falls inside the stated range.
By their numbers in this assay, from the lowest: compound 4; then compound 2; then compound 3. At a limit, above all of these: compound 1.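

Among these compounds, at this aromatic carbon of the shared core, this assay does respond to the change: with the (1-bromoethenyl)carbonyl group kept and the same atoms joined differently, 4-methylphenyl in place of benzyl gives a 2.5-fold lower number from compound 2 to compound 4 (0.39 log units; beyond the scatter) as the first measured step at this position, modest but beyond the scatter. Nothing measured here accounts for this step. The compounds shown leave open whether a carboxylic acid or a longer chain on this phenyl ring would move the number further, and whether 4-methylphenyl gives a similar step without the (1-bromoethenyl)carbonyl group.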